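Allyloxycarbonyl to ethoxycarbonyl: expectation for compound 4

The source may hold more compounds than are shown below. What is called first, only, known or untested is meant among the compounds shown, and "the series" means these compounds.

Measured so far in a functional assay on the whole organism for inhibition, with Artemia salina as the target; a higher number here means a weaker inhibitor of growth, a lower number a stronger inhibitor of growth:
compound 1 `CO[C@H]1C[C@H](O[Si](C)(C)C(C)(C)C)O[C@@H](C)/C1=C\C=N\O`, 0.002 ug/mL
compound 2 `CO[C@H]1C[C@H](O[Si](C)(C)C(C)(C)C)O[C@@H](C)/C1=C\C(=O)O`, 0.002 ug/mL
compound 3 `C=CCOC(=O)/C=C1/[C@H](C)O[C@@H](O[Si](C)(C)C(C)(C)C)C[C@@H]1OC`, 0.002 ug/mL

On the numbers shown, compound 3 stands level with compound 1 and compound 2 at the digits given; its nearest neighbour is compound 1 and its furthest compound 2, both within the scatter. Within the data shown here, the only single-point step among the measured compounds is no change at the digits printed from compound 1 to compound 2 (within the scatter), a swap on the double-bonded chain carbon that leaves the read-out unchanged. Among the measured compounds shown here, no measured step touches the group that compound 3 carries on that carbon, and compound 3 differs from compound 1 in more than one place, so of that pair only the two values can be compared, and they read the same.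

Compound 4 `CCOC(=O)/C=C1/[C@H](C)O[C@@H](O[Si](C)(C)C(C)(C)C)C[C@@H]1OC` is the next member. Against compound 3 the change is methyl in place of vinyl on a saturated chain carbon bound to an oxygen next to a carbonyl group. For the measured compounds named here, no step in the set bears directly on this change; the one step recorded, in this assay, was flat, and all three measured compounds sit at one value. The expected step is therefore none beyond the scatter, no change at the digits printed from compound 3 to compound 4 (within the scatter). Compound 4 is estimated at 0.002 ug/mL, with a range from 0.001 ug/mL to 0.004 ug/mL.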

Compound 4, minimum inhibitory concentration: 0.01 ug/mL
Compound 4: middle estimate off by 2.3 two-fold dilutions, on the low side; measured number above the stated range.
By their numbers in this assay, from the lowest: compounds 1, 2 and 3 (each within the scatter of the next); then compound 4.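

In this assay, methyl in place of vinyl on a saturated chain carbon bound to an oxygen next to a carbonyl group gives a number 2.3 two-fold dilutions higher from compound 3 to compound 4 (beyond the scatter), whereas no change at the digits printed from compound 1 to compound 2 (within the scatter). This position therefore responds to a change in this assay, and the outcome depends on the chain itself, since allyloxycarbonyl and ethoxycarbonyl differ only in allyl against ethyl. No measurement here accounts for the step.

The compounds shown do not separate the double bond from chain length, as allyl to ethyl alters both at once; a propyl group, saturated like ethyl and as long as allyl, would tell these two apart. The silyl ether stays the same across all of the compounds shown, so the effect of replacing it with a free hydroxyl on the read-out in this assay remains open, as does whether the allyl to ethyl step would hold on a core without that group.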